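The source may report more compounds than this note shows. Statements on the series, on what has been measured and on what is new or still open speak of the compounds shown alone.

Measured compounds in a physicochemical assay for solubility, using the shake flask method, measured as kinetic solubility, with a stated time of 20 h, at pH 2; a higher number here means a more soluble compound, a lower number a less soluble compound:
Compound 1, `FC(F)(F)Oc1ccc(-c2nc3cnc(Nc4ccccn4)cc3[nH]2)cc1`, gives 26000 nM.
Compound 2, `COc1ccnc(Nc2cc3[nH]c(-c4cccc(C(F)(F)F)c4)nc3cn2)c1`, gives only a limit, < 5000 nM.
Compound 3, `Fc1ccc(-c2nc3cnc(Nc4ccccn4)cc3[nH]2)cc1F`, gives 125000 nM.

Compound 2 is the one of the three for which this assay reports no number but a limit, (the limit of < 5000 nM in this assay, at which 1 of the 3 values shown sits); where its solubility actually lies beneath that cut-off is not known. For the measured compounds named here, compounds 1 and 3 both carry numbers, and compound 3 sits above compound 1, but these compounds differ from each other in more than one place, so no single step is drawn between any pair of them.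

Compound 4, `N#Cc1ccc(Nc2cc3[nH]c(-c4cccc(C(F)(F)F)c4)nc3cn2)nc1`, is not yet measured. It differs from compound 2 in one place: 5-cyanopyridin-2-yl in place of 4-methoxypyridin-2-yl on a nitrogen on an aromatic ring. Going by the values given here, no measured step of this kind exists, so there is nothing to size the change against. Compound 2 starts from a limit in this assay, < 5000 nM, which leaves the starting point itself open. The expectation is a step from compound 2 to compound 4 of a step that the limit leaves unreadable from compound 2 to compound 4, nothing beyond the scatter in either direction. Compound 4 is estimated at 4000 nM, within 1000 nM to 15000 nM, with a fair chance that this assay again reports only a limit.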

Compound 4, solubility: < 5000 nM
Compound 4 gave a limit, no number; the forecaster's own chance of this, stated with the estimate: 60%; the middle value does not contradict the limit.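

Compound 2 and compound 4 each give only a limit in this assay, so no step can be read between them: the limit of < 5000 nM in this assay, at which 2 of the 4 values shown sit.

Still open, going by these compounds, is where compound 2 and compound 4 actually lie, and so whether 5-cyanopyridin-2-yl in place of 4-methoxypyridin-2-yl shifts the solubility read-out at all.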